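Aryl vinyl sulfide series: carboxylate to bromo-nitro swap

The compounds below may be only part of what the source reports. "The series", "measured", "known", "first", "only" and "open" are said of these compounds alone.

Measured so far in a functional assay on DU-145 cells (Homo sapiens) for inhibition, read by trypan blue exclusion, with a stated time of 96 h; a higher number here means a weaker inhibitor of growth, a lower number a stronger inhibitor of growth:
compound 1 `O=C(/C(=C\c1ccc(I)cc1)Sc1ccc(Br)cc1)c1ccc(Br)cc1` gives 1000 nM
compound 2 `O=C(O)c1ccc(/C=C(/SCc2ccc(Cl)cc2)C(=O)c2ccc(C(=O)O)cc2)cc1` returns only a limit, > 100000 nM
compound 3 `COc1cc(OC)c(/C=C(\C(=O)c2ccc(Cl)cc2)S(=O)(=O)c2ccc(C)cc2)c(OC)c1` gives 25000 nM

Compound 1 and compound 3 each return a number in this assay. Among the compounds with values here, compound 2 does not: it stands at the limit of > 100000 nM in this assay, at which 1 of the 3 values shown sits, and it is the one compound of the three that carries a carboxylic acid on both aryl rings. Within the data shown here, no pair of measured compounds differs in a single place, so no measured step is available to lean on.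

Compound 4 `O=C(O)c1ccc(C(=O)/C(=C\c2ccc(Br)c([N+](=O)[O-])c2)SCc2ccc(Cl)cc2)cc1` is compound 2 with one change: 4-bromo-3-nitrophenyl in place of 4-carboxyphenyl on a double-bonded chain carbon bound to a double-bonded chain carbon. The carboxylic acid on the benzoyl side is kept.

Compound 4 thus moves part of the way from compound 2 toward compound 1, which holds halogenated aryl groups on both sides and gives 1000 nM. The step of an at least 3.3-fold lower number from compound 2 to compound 4 (0.52 log units; beyond the scatter) is expected to run toward stronger inhibition and beyond the usual scatter, though because compound 2 sits at the limit of > 100000 nM in this assay, at which 1 of the 3 values shown sits, its true size cannot be fixed. With one carboxylic acid still present, compound 4 is not expected to reach compound 1. For compound 4 in this assay the estimate is 30000 nM, within 5000 nM to 150000 nM.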

Compound 4, concentration for 50% growth inhibition: < 1000 nM
Compound 4: no number, only a limit; the forecaster's own chance of this, stated with the estimate: 35%; at least 30-fold (1.47 log units) between middle value and limit.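

In this assay, within the data shown here, the one change of 4-bromo-3-nitrophenyl in place of 4-carboxyphenyl on a double-bonded chain carbon bound to a double-bonded chain carbon gives an at least 100-fold lower number from compound 2 to compound 4 (2.00 log units; beyond the scatter), the only measured step so far. It shows that this place strongly governs the read-out, and that the carboxylic acid kept on the benzoyl side of compound 4 does not by itself abolish growth inhibition, which compound 2, with its two carboxylic acids, could not show. Compound 4 returns only a limit, so the step has a floor but no fixed size: the limit of < 1000 nM in this assay, at which 1 of the 4 values shown sits.

The compounds shown leave open how much of the step belongs to the bromo group and how much to the nitro group, and whether a phenyl ring carrying only one of them at this place would hold the gain. Also open, on these data alone, is what an amine or a methyl ester in place of the remaining carboxylic acid would do in this assay.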